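Phenyl in place of thiophen-2-yl on compound 1

This account rests on a few compounds, and the source may have more. Where it says the series, first, only, none or still open, it means among the compounds named here.

Compound 1 `Oc1cccc(-c2cc(-c3ccc(Cl)cc3)nc(-c3cccs3)c2)c1`: 9280 nM
Compound 2 `Oc1cccc(-c2cc(-c3cccc(Cl)c3)nc(-c3cccs3)c2)c1`: 2610 nM
Compound 3 `Oc1ccc(-c2cc(-c3cccc(Cl)c3)nc(-c3ccco3)c2)cc1`: 8020 nM

Within the data shown here, in a functional assay on HCT-15 cells (Homo sapiens) for cytotoxicity, read by CCK-8 assay and cell counting, with a stated time of 2 days (a lower number here means a stronger inhibitor, a higher number a weaker inhibitor), compound 1 gives the highest of the three numbers; compound 3 lies within the scatter of it, while the one measured step, a 3.6-fold lower number from compound 1 to compound 2 (0.55 log units; beyond the scatter), stands beyond the scatter. Compound 4 `Oc1cccc(-c2cc(-c3ccccc3)nc(-c3ccc(Cl)cc3)c2)c1` differs from compound 1 at a single place: phenyl in place of thiophen-2-yl on an aromatic carbon. Among the measured compounds shown here, no measured step touches this group; the step of a 3.6-fold lower number from compound 1 to compound 2 (0.55 log units; beyond the scatter) concerns the chlorophenyl ring, and compound 3 differs from compound 1 in more than one place, so neither gives a clean guide. Compound 4 is therefore expected to sit close to compound 1, the estimated step of a 1.1-fold lower number from compound 1 to compound 4 (0.04 log units; within the scatter) staying within the scatter. The estimate for compound 4 is 8500 nM, between 3000 nM and 25000 nM.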

Compound 4, half-maximal inhibitory concentration: 8110 nM
Compound 4: middle estimate off by 1.0-fold (0.02 log units), on the high side; the range from low to high includes it.
By their numbers in this assay, from the lowest: compound 2; then compounds 3, 4 and 1 (each within the scatter of the next).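

In this assay, among these compounds, replacing thiophen-2-yl by phenyl next to the ring nitrogen (a 1.1-fold lower number from compound 1 to compound 4 (0.06 log units; within the scatter)) gives the first clean reading at this position. With the 3-hydroxyphenyl and 4-chlorophenyl groups in place, the ring sulfur is not needed to hold the number, and a six-membered carbon ring serves as well as the five-membered ring. No measurement given here offers a reason for this. As far as these compounds go, it remains open whether the same replacement holds on compound 2, with its 3-chlorophenyl group, and whether an amine or a carboxylic acid on this phenyl ring would shift the number.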